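Morpholine in place of diisopropylamine on the dithiocarbamate

A few compounds are considered here, and "the series" means these few. Any claim that something is new, unique, unknown or untested is made for them only; others in the source may bear on it.

Measured compounds and their values in a functional assay on SW480 cells (Homo sapiens) for antiproliferative activity, read by MTT assay, with a stated time of 72 h; a higher number here means a weaker inhibitor, a lower number a stronger inhibitor:
compound 1 `O=c1c(Cl)c(CSC(=S)N2CCCCC2)oc2ccccc12`: 690 nM
compound 2 `CC(C)N(C(=S)SCc1oc2ccccc2c(=O)c1Cl)C(C)C`: 18100 nM
compound 3 `O=c1cc(CSC(=S)N2CCOCC2)oc2cc(Cl)ccc12`: > 25000 nM

Compound 2 gives the highest of the two numbers in this assay. Its nearest neighbour, compound 1, differs from it in one place, and the step of a 26-fold higher number from compound 1 to compound 2 (1.42 log units; beyond the scatter) shows how much the exchange of piperidin-1-yl for diisopropylamino on the thiocarbonyl carbon raised the number. Among the compounds with values here, for compound 3 this assay gives only a limit, > 25000 nM, and not a number (the limit of > 25000 nM in this assay, at which 1 of the 3 values shown sits); compound 3 also carries morpholin-4-yl and a chlorine in a different place than compound 2, so no single step links them.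

Compound 4 `O=c1c(Cl)c(CSC(=S)N2CCOCC2)oc2ccccc12` is not yet measured. It differs from compound 2 by morpholin-4-yl in place of diisopropylamino on a thiocarbonyl carbon. Within the data shown here, the one measured step that bears on this change is a 26-fold higher number from compound 1 to compound 2 (1.42 log units; beyond the scatter), in which a six-membered non-aromatic ring on the thiocarbonyl carbon gave the far lower number; compound 4 restores a ring of that kind. A large step downward is therefore expected, a 9.1-fold lower number from compound 2 to compound 4 (0.96 log units; beyond the scatter), though morpholin-4-yl need not match piperidin-1-yl exactly. Compound 4 is estimated at 2000 nM, in the range 500 nM to 8000 nM.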

Compound 4, half-maximal inhibitory concentration: 1800 nM
Compound 4: the middle estimate sits 1.1-fold (0.05 log units) above what was measured; measured number inside the range.
By their numbers in this assay, from the lowest: compound 1; then compound 4; then compound 2. At a limit, above all of these: compound 3.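

In this assay, exchanging diisopropylamino for morpholin-4-yl on the thiocarbonyl carbon gives a 10-fold lower number from compound 2 to compound 4 (1.00 log units; beyond the scatter), so with the chlorine kept in the place it has in compound 1, the lower number no longer rests on piperidin-1-yl alone. The two rings are still not interchangeable at this position: the change from piperidin-1-yl to morpholin-4-yl gives a 2.6-fold higher number from compound 1 to compound 4 (0.42 log units; beyond the scatter). Morpholin-4-yl thus recovers a large part, but not all, of what was lost with diisopropylamino.

Going by these compounds, compound 3 also carries morpholin-4-yl but has its chlorine in a different place, and its result is only a limit: the limit of > 25000 nM in this assay, at which 1 of the 4 values shown sits. It remains open whether a smaller open-chain amine such as dimethylamino, or a piperazin-1-yl ring, would fall with the two rings or with diisopropylamino.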